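Ring amines in place of cyclohexyl(methyl)amino on the core

A few compounds are considered here, and "the series" means these few. Any claim that something is new, unique, unknown or untested is made for them only; others in the source may bear on it.

Compound 1 `CN(c1ccc2cc(NC(=O)CCc3ccc(C(F)(F)F)cc3)ccc2n1)C1CCCCC1` carries cyclohexyl(methyl)amino on an aromatic carbon of the shared core. Among the compounds with values here, in a functional assay on HEK293 cells for activation of melanin-concentrating hormone receptor 1 (Rattus norvegicus), read by inositol phosphate accumulation (a higher number here means that more compound is needed for the effect, a lower number that less compound is needed), compound 1 gives 1200 nM, the highest of the three numbers measured so far. Compound 2 `O=C(CCc1ccc(C(F)(F)F)cc1)Nc1ccc2nc(N3CC4CC3CO4)ccc2c1` gives 70 nM in this assay, and compound 3 `O=C(CCc1ccc(C(F)(F)F)cc1)Nc1ccc2nc(N3CCCCC3)ccc2c1` gives 110 nM.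

Compound 4 `O=C(CCc1ccc(C(F)(F)F)cc1)Nc1ccc2nc(N3CC4CCC3C4)ccc2c1` is not yet measured. Relative to compound 1 the change is a group of 7 heavy atoms (6 carbon, 1 nitrogen; one five-membered non-aromatic ring of carbon only, one five-membered non-aromatic ring with 1 hetero atom) in place of a group of 8 heavy atoms (7 carbon, 1 nitrogen; one six-membered non-aromatic ring of carbon only), on an aromatic carbon; the group that enters holds one five-membered non-aromatic ring of carbon only and one five-membered non-aromatic ring with 1 hetero atom, and it sits next to the ring nitrogen of the core.

Within the data shown here, two measured steps bear on this change: a 17-fold lower number from compound 1 to compound 2 (1.23 log units; beyond the scatter) and an 11-fold lower number from compound 1 to compound 3 (1.04 log units; beyond the scatter). Both replace the same cyclohexyl(methyl)amino with a ring amine, and both give a large lower number. Between the two ring amines themselves, a 1.6-fold higher number from compound 2 to compound 3 (0.20 log units; within the scatter), so within these three compounds the exact form of the ring amine has made little difference. Compound 4 is therefore expected to show a step of about a 13-fold lower number from compound 1 to compound 4 (1.12 log units; beyond the scatter), a large lower number. The expected value for compound 4 in this assay is 90 nM, with a range from 35 nM to 250 nM.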

Compound 4, half-maximal effective concentration: 150 nM
Compound 4: the middle estimate sits 1.7-fold (0.22 log units) below what was measured, and the stated range covers the measured number.
By their numbers in this assay, from the lowest: compounds 2, 3 and 4 (each within the scatter of the next, the first and the last beyond it); then compound 1.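

In this assay, a third ring amine on the aromatic carbon next to the ring nitrogen again gives a lower number than cyclohexyl(methyl)amino, with an 8.0-fold lower number from compound 1 to compound 4 (0.90 log units; beyond the scatter) as the step, so the direction now holds for compound 2, compound 3 and compound 4 with no exception among the compounds shown. The ring amines are no longer all alike: a 1.4-fold higher number from compound 3 to compound 4 (0.13 log units; within the scatter) stays within the scatter, but a 2.1-fold higher number from compound 2 to compound 4 (0.33 log units; beyond the scatter) lies just beyond it, a modest step in which the entering group holds only carbon and nitrogen while the group of compound 2 also holds an oxygen. No measurement on these compounds accounts for that small separation or for the larger step away from cyclohexyl(methyl)amino.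

The compounds shown leave open whether that larger step follows from closing the amine into a ring or from removing the cyclohexyl group, which a small open-chain amine such as dimethylamino on the same carbon would help to separate. On these data alone, whether the oxygen matters outside the bridged group also remains open, and morpholin-4-yl set against piperidin-1-yl would test this directly.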